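Oxygen to sulfur on the amide of the shared core

This account rests on a few compounds, and the source may have more. Where it says the series, first, only, none or still open, it means among the compounds named here.

Compound 1 `CO[C@@H]1C[C@@H](C(=O)NCCN(C)C)N(C(=O)NCc2ccc(C(=O)N3CCCCc4sccc43)cc2Cl)C1`: 1800 nM
Compound 2 `CO[C@@H]1C[C@@H](C(=S)N2CCC(N3CCCC3)CC2)N(C(=O)NCc2ccc(C(=O)N3CCCCc4sccc43)cc2Cl)C1`: 100 nM
Compound 3 `CO[C@@H]1C[C@@H](C(=O)N2CCCN(C)CC2)N(C(=O)NCc2ccc(C(=O)N3CCCCc4sccc43)cc2Cl)C1`: 1300 nM

Three compounds share one core and were tested in an assay on isolated protein with Vasopressin V2 receptor (Homo sapiens) as the target; on this read-out higher numbers stand for an effect only at larger amounts of compound and lower numbers for an effect already at smaller amounts. Compound 3 stands second highest of the three numbers. Its nearest neighbour is compound 1, and the step of a 1.4-fold lower number from compound 1 to compound 3 (0.14 log units; within the scatter) is within the scatter, so the two cannot be told apart. Compound 2 stands far lower and beyond the scatter.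

Compound 4 `CO[C@@H]1C[C@@H](C(=S)N2CCCN(C)CC2)N(C(=O)NCc2ccc(C(=O)N3CCCCc4sccc43)cc2Cl)C1` has not yet been measured. It differs from compound 3 in one place: a group of 10 heavy atoms (7 carbon, 2 nitrogen, 1 sulfur; one seven-membered non-aromatic ring with 2 hetero atoms) in place of a group of 10 heavy atoms (7 carbon, 2 nitrogen, 1 oxygen; one seven-membered non-aromatic ring with 2 hetero atoms), on a saturated ring carbon. Among the measured compounds shown here, the sulfur-bearing group that enters is the same kind of change that separates compound 2 from compound 1 and compound 3, but compound 2 also carries a different ring on that sulfur-bearing carbon, so no single measured step isolates the oxygen-to-sulfur exchange. For the measured compounds named here, the only hint is that the one sulfur-bearing compound, compound 2, gives the lowest number of the three.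

On that basis compound 4 is expected to move to a lower number than compound 3, by a step estimated as a 2.9-fold lower number from compound 3 to compound 4 (0.46 log units; beyond the scatter), but with wide uncertainty. The estimate for compound 4 in this assay is 450 nM, within a range from 120 nM to 1600 nM.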

Compound 4, half-maximal effective concentration: 230 nM
The estimate for compound 4 lay 2.0-fold (0.29 log units) above the measured number; measured number inside the range.
By their numbers in this assay, from the lowest: compound 2; then compound 4; then compounds 3 and 1 (each within the scatter of the next).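

The exchange of oxygen for sulfur now stands alone in this assay: with the 4-methyl-1,4-diazepan-1-yl group kept, it gives a 5.7-fold lower number from compound 3 to compound 4 (0.75 log units; beyond the scatter) and so lowers the number on its own, without help from any other change. Sulfur does not account for everything, since the two thiocarbonyl compounds still differ by a 2.3-fold higher number from compound 2 to compound 4 (0.36 log units; beyond the scatter) when only the ring on that carbon changes, so the ring counts as well. The largest new step, a 7.8-fold lower number from compound 1 to compound 4 (0.89 log units; beyond the scatter), combines the sulfur with a change from the open chain to the ring, and it cannot be split into those two parts from this pair alone, although the matching carbonyl pair shows only a 1.4-fold lower number from compound 1 to compound 3 (0.14 log units; within the scatter) within the scatter.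

Still open, going by these compounds, is whether sulfur gives a step of similar size with other groups on this carbon, such as 4-(pyrrolidin-1-yl)piperidin-1-yl on a plain carbonyl, the (2-(dimethylamino)ethyl)amino chain on a thiocarbonyl, or a morpholine ring. Nothing shown here explains why the number falls with sulfur.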